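A Carbamate Chain Rearranged on a Shared Quinone Core

The source may report more compounds than this note shows. Statements on the series, on what has been measured and on what is new or still open speak of the compounds shown alone.

Compound 1 `CC1=C(N2CC2)C(=O)C(CC(C)OC(N)=O)=C(N2CC2)C1=O` stands lowest of the two compounds measured in a functional assay on L1210 cells (Mus musculus), with a stated time of 12 days (on this read-out higher numbers stand for higher potency (the scale is a negative logarithm) and lower numbers for lower potency), where compound 1 gives 6.14. Its only measured companion, compound 2 `O=C1C(CCO)=C(N2CC2)C(=O)C(CCO)=C1N1CC1`, reaches 6.54 in this assay, a gap that lies beyond the usual scatter of the read-out. Compound 3 `CC1=C(N2CC2)C(=O)C(CCCOC(N)=O)=C(N2CC2)C1=O` has not yet been measured. It holds the same atoms as compound 1, joined differently: a group of 6 heavy atoms (3 carbon, 1 nitrogen, 2 oxygen; no ring) in place of a group of 6 heavy atoms (3 carbon, 1 nitrogen, 2 oxygen; no ring), on a saturated chain carbon bound to a double-bonded ring carbon. The entering 2-(carbamoyloxy)ethyl group sits on a saturated chain carbon bound to a double-bonded ring carbon. Among the compounds with values here, no measured pair shows the effect of such a rearrangement, so nothing here anchors the size of the step; with the shared core untouched, no shift beyond the scatter is expected in either direction. Compound 3 is therefore expected to give 6.3, with a range from 5.7 to 6.9, in this assay. This estimate means a step of a number 0.16 log units higher from compound 1 to compound 3 (within the scatter), which is expected to stay within the scatter.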

Compound 3, logarithm of the reciprocal of the active concentration, log(1/C): 6.18
Beside the measured number, compound 3's estimate is 0.12 log units above it, and the stated range covers the measured number.
By their numbers in this assay, from the lowest: compounds 1 and 3 (each within the scatter of the next); then compound 2.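

Within the data shown here, at this place, on a saturated chain carbon bound to a double-bonded ring carbon, the 2-(carbamoyloxy)ethyl group gives the first step that can be read in this assay, which is a number 0.04 log units higher from compound 1 to compound 3 (within the scatter). The two isomeric groups thus read alike here, and on this shared core the read-out does not separate one arrangement of these atoms from the other. No supporting data bear on this result, so it stands as an observation alone.

The compounds shown cover only this one rearrangement, so they leave open how far the result extends to groups of other make-up at this place. An amine or a carboxylic acid in place of the carbamate, or a longer chain carrying the carbamate, remains to be read on this core.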